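This account rests on a few compounds, and the source may have more. Where it says the series, first, only, none or still open, it means among the compounds named here.

Working notes on the series. Going by the values given here, compound 2 `Cc1ccc(/C=N/NC(N)=S)c2ccccc12` is the only member that returns a number in a toxicity assay on MRC5 cells (Homo sapiens) for cytotoxicity, read by MTT assay, with a stated time of 72 h; a higher number here means that more compound is needed for the effect, a lower number that less compound is needed; here compound 2 reads 37000 nM. Compound 1 `NC(=S)N/N=C/c1cn(CCCc2ccccc2)c2ccccc12` gives only a limit in this assay, > 200000 nM. Compound 3 `CN(C)c1ccc(/C=N/N=C(/N)S)c2ccccc12` likewise gives only a limit in this assay, > 200000 nM. Among the compounds with values here, the set is therefore dominated by the limit of > 200000 nM in this assay, at which 2 of the 3 values shown sit, and compound 2 stands alone as the single resolved value, with no measured step available to set it against. Compound 4 `NC(=S)N/N=C/c1ccc(OCc2ccccc2)c2ccccc12` has not yet been measured; it differs from compound 2 by benzyloxy in place of methyl on an aromatic carbon. Within the data shown here, no measured pair shows what this exchange does in this assay, so direction and size rest on expectation alone; the step is expected to be a 1.4-fold higher number from compound 2 to compound 4 (0.13 log units; within the scatter), a modest move that may not exceed the scatter. Compound 4 is accordingly expected near 50000 nM in this assay, within a range from 15000 nM to 200000 nM.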

Compound 4, half-maximal effective concentration: 29000 nM
Beside the measured number, compound 4's estimate is 1.7-fold (0.24 log units) above it, within the range that was stated.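

In this assay, the exchange of methyl for benzyloxy on this aromatic carbon, para to a group of 6 heavy atoms, now has a measured step: a 1.3-fold lower number from compound 2 to compound 4 (0.11 log units; within the scatter). Going by these compounds alone, this position therefore accepts benzyloxy, with its added six-membered aromatic ring of carbon only and its hydrogen-bond acceptor, without a move beyond the scatter, something no earlier compound could show. Within the data shown here, compound 2 and compound 4 are the only members with resolved numbers, and the rest of the set gives limits: the limit of > 200000 nM in this assay, at which 2 of the 4 values shown sit.

Going by these compounds, how much of the benzyloxy reading belongs to its oxygen and how much to its ring stays open, and a methoxy group at this aromatic carbon would separate the two. On these data alone, what a carboxylic acid or a longer alkoxy chain would give here also remains open.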